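This account rests on a few compounds, and the source may have more. Where it says the series, first, only, none or still open, it means among the compounds named here.

In a physicochemical assay for solubility (on this read-out lower numbers stand for lower solubility and higher numbers for higher solubility), compound 3 `CNC(=O)c1cc(C(N)=O)cc2c1O[C@H](CF)[C@H]2c1ccccc1` stands at a limit, >= 128 ug/mL, and not at a number. Compound 2 `CNC(=O)c1cc(C(N)=O)cc2c1OC[C@H]2c1ccccc1` also gives only a limit, >= 144 ug/mL. Compound 1 `CNC(=O)c1cc(C(=O)N[C@H]2[C@@H]3COC[C@@H]32)cc2c1OC[C@H]2c1ccncc1` likewise gives only a limit, >= 184 ug/mL. Compound 4 `CNC(=O)c1cc(C(=O)NC)c2c(c1)[C@H](c1ccccc1)[C@@H](CF)O2` differs from compound 3 by methyl in place of hydrogen on an amide-type nitrogen. Among the compounds with values here, the only measured step is a step that the two limits leave unreadable from compound 2 to compound 3. That step is a different change, fluoromethyl in place of hydrogen on a saturated ring carbon, and it gives no size to carry over. Within the data shown here, no measured pair shows the methyl change, so nothing beyond the scatter is expected in this assay, and the expected outcome is a step that the limit leaves unreadable from compound 3 to compound 4. For compound 4 the estimate is 130 ug/mL, with an expected range of 50 ug/mL to 200 ug/mL.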

Compound 4, solubility: >= 149 ug/mL
Compound 4: only a limit was reported; the forecaster's own chance of this, stated with the estimate: 60%; middle value at least 1.1-fold (0.05 log units) away from the limit.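

Within the data shown here, compound 3 and compound 4 both give only limits in this assay, and no step between them can be read. The compounds shown leave open the actual solubility of all four compounds and the size of either change.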